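Growth inhibition: from compound 2 to compound 3

A few compounds are considered here, and "the series" means these few. Any claim that something is new, unique, unknown or untested is made for them only; others in the source may bear on it.

In a functional assay on NCI-H23 cells (Homo sapiens) for inhibition, read by sulforhodamine B assay, with a stated time of 48 h (a higher number here means a weaker inhibitor of growth, a lower number a stronger inhibitor of growth), compound 1 (`Cc1ccc(C2=NN(c3ccc(S(C)(=O)=O)cc3)C(=O)CC2)cc1`) gives 2500 nM and compound 2 (`Cc1cc(O)ccc1C1=NN(c2ccc(S(C)(=O)=O)cc2)C(=O)CC1`) gives 38500 nM. Compound 2 thus holds the higher of the two numbers and is the weaker inhibitor of growth of this pair.

Compound 3 (`CCc1ccc(C2=NN(c3ccc(S(C)(=O)=O)cc3)C(=O)CC2)cc1`) has not yet been measured. It carries 4-ethylphenyl in place of 4-hydroxy-2-methylphenyl on a carbon with a double bond to nitrogen.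

Among the compounds with values here, one measured step bears on this change: a 15-fold higher number from compound 1 to compound 2 (1.19 log units; beyond the scatter), a large step that brought in 4-hydroxy-2-methylphenyl at the same place. The step to compound 3 removes that group again, so a step of similar size is expected in the opposite direction, toward a lower number in this assay, near compound 1 at 2500 nM. The estimated change is a 14-fold lower number from compound 2 to compound 3 (1.14 log units; beyond the scatter). Compound 3 is expected at 2800 nM, with an estimated range of 1000 nM to 8000 nM.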

Compound 3, concentration for 50% growth inhibition: 3190 nM
Compound 3: the middle estimate sits 1.1-fold (0.06 log units) below what was measured, within the range that was stated.
By their numbers in this assay, from the lowest: compounds 1 and 3 (each within the scatter of the next); then compound 2.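

In this assay, the step of a 12-fold lower number from compound 2 to compound 3 (1.08 log units; beyond the scatter) shows that this position is not closed to a large group of 8 heavy atoms: 4-ethylphenyl keeps the number near that of compound 1, so the loss belongs to the 4-hydroxy-2-methylphenyl group rather than to the size of the group at this place. The step of a 1.3-fold higher number from compound 1 to compound 3 (0.11 log units; within the scatter) lies within the scatter, so methyl in place of hydrogen on the saturated chain carbon leaves growth inhibition unchanged as far as this assay can tell. No measurement in hand accounts for these results.

Still open, going by these compounds, is whether the hydroxyl or the 2-methyl group carries the loss, since the two enter together in compound 2. Also open, on these data alone, is how a longer chain such as propyl, an amine or a carboxylic acid would read at this place.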